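Hydrazone ureas on a shared core: removing one phenolic hydroxy

The compounds below may be only part of what the source reports. "The series", "measured", "known", "first", "only" and "open" are said of these compounds alone.

Measured so far:
compound 1, `Cn1ncnc1-c1cc(Oc2ccc(NC(=O)N/N=C/c3ccccc3)cc2F)ccn1`: > 100000 nM
compound 2, `CN(C)CCn1cnnc1-c1cc(Oc2ccc(NC(=O)N/N=C/c3ccc(O)c(O)c3)cc2F)ccn1`: > 100000 nM

Both values come from a functional assay on U-87MG ATCC cells (Homo sapiens) for cytotoxicity, read by MTT assay, with a stated time of 72 h; a higher number here means a weaker inhibitor, a lower number a stronger inhibitor. For compound 1 the value > 100000 nM is a limit of the assay and not a number. For compound 2 the value > 100000 nM is likewise a limit, so compound 2 stands only at the edge of what this assay can report, as does every value shown (the limit of > 100000 nM in this assay, at which 2 of the 2 values shown sit).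

Compound 3, `CN(C)CCn1cnnc1-c1cc(Oc2ccc(NC(=O)N/N=C/c3cccc(O)c3)cc2F)ccn1`, is not yet measured in this assay. It differs from compound 2 as follows: hydrogen in place of hydroxy on an aromatic carbon.

Going by the values given here, with no measured step between any two compounds, there is no numerical basis for a direction. Since compound 2 gives only the limit > 100000 nM, the step from compound 2 to compound 3 is expected to be small, within the scatter, as a number no higher from compound 2 to compound 3 (the limit leaves the size open). Compound 3 is expected at about 100000 nM, between 30000 nM and 300000 nM, most likely reported again as a limit.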

Compound 3, half-maximal inhibitory concentration: > 100000 nM
Compound 3: no number, only a limit (the forecaster's own chance of this, stated with the estimate: 80%); the middle value lies on the limit itself.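

No step can be read from compound 2 to compound 3, since in this assay each gives only a limit and not a number: the limit of > 100000 nM in this assay, at which 3 of the 3 values shown sit.

The compounds shown leave open whether 3,4-dihydroxyphenyl and 3-hydroxyphenyl differ at all, and whether any compound on the shared core gives a number in this assay.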